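From 2-chlorobenzyl to 4-cyanobenzyl at one position

The compounds below may be only part of what the source reports. "The series", "measured", "known", "first", "only" and "open" are said of these compounds alone.

- compound 1 `CCOCCOn1c(-c2cccc(C#N)c2)nc(C)c1C(=O)OCC` gives 6250 nM
- compound 2 `CCOC(=O)c1c(C)nc(-c2cccc(C#N)c2)n1OCc1ccncc1` gives 6200 nM
- compound 3 `CCOC(=O)c1c(C)nc(-c2cccc(C#N)c2)n1OCc1ccccc1Cl` gives 8710 nM

In a functional assay on a cell-free system (plasma, Oryctolagus cuniculus) for inhibition, with stated times of 5 min, 1 min and 6 min (a higher number here means a weaker inhibitor, a lower number a stronger inhibitor), compound 3 stands level with compound 1 and compound 2, since all three numbers lie within the scatter of one another. Compound 4 `CCOC(=O)c1c(C)nc(-c2cccc(C#N)c2)n1OCc1ccc(C#N)cc1` makes one change (4-cyanophenyl in place of 2-chlorophenyl on a saturated chain carbon bound to an oxygen on an aromatic ring), with 4-cyanophenyl in place of 2-chlorophenyl on a saturated chain carbon bound to an oxygen on an aromatic ring. Three swaps at that same place have been measured, namely a 1.0-fold lower number from compound 1 to compound 2 (0.00 log units; within the scatter) and a 1.4-fold higher number from compound 1 to compound 3 (0.14 log units; within the scatter) and a 1.4-fold higher number from compound 2 to compound 3 (0.15 log units; within the scatter) and each stays within the scatter. Going by these compounds, the 4-cyanophenyl group itself is untested, but no step beyond the scatter is expected in this assay (a 1.3-fold lower number from compound 3 to compound 4 (0.13 log units; within the scatter)). Compound 4 is estimated at 6500 nM (expected range 2500 nM to 15000 nM).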

Compound 4, half-maximal inhibitory concentration: 4240 nM
Estimate against measurement, compound 4: 1.5-fold (0.19 log units) above; the range from low to high includes it.
By their numbers in this assay, from the lowest: compounds 4, 2, 1 and 3 (each within the scatter of the next, the first and the last beyond it).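

Among these compounds, the step of a 2.1-fold lower number from compound 3 to compound 4 (0.31 log units; beyond the scatter) in this assay is modest, but it is the first at this place to lie beyond the scatter, so a swap here can move the number. The other two steps, a 1.5-fold lower number from compound 2 to compound 4 (0.17 log units; within the scatter) and a 1.5-fold lower number from compound 1 to compound 4 (0.17 log units; within the scatter), stay within the scatter, so compound 4 separates from compound 3 only. No evidence is available to explain this step.

Whether the nitrile or the loss of the chlorine accounts for the step stays open. So does what an amine or a carboxylic acid at this place would do to the number.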